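This account rests on a few compounds, and the source may have more. Where it says the series, first, only, none or still open, it means among the compounds named here.

Of the compounds shown here, two have been measured in an assay on isolated protein for binding affinity to corticotropin-releasing factor receptor 1 (Rattus norvegicus); a higher number here means a weaker inhibitor, a lower number a stronger inhibitor. Compound 1, with the structure `Cc1cc(C)c2ccn(-c3ccc(C(C)C)cc3Br)c2n1`, gives 47 nM. Compound 2, with the structure `Cc1cc(Cl)c2c(C#N)cn(-c3ccc(C(C)C)cc3Br)c2n1`, gives 722 nM, the higher of the two numbers: the gap from compound 1 to compound 2 is beyond the usual scatter of repeated measurements, so compound 2 is the weaker binder of the pair.

The next compound, compound 3, has the structure `Cc1cc(Cl)c2ccn(-c3ccc(C(C)C)cc3Br)c2n1`. It differs from compound 2 in one place: hydrogen in place of cyano on an aromatic carbon. Compound 1, which also carries no cyano group, sits at 47 nM, and that suggests the move from compound 2 to compound 3 should bring the number down by a clear margin rather than leave it unchanged. The step from compound 2 to compound 3 is expected to be a 6.0-fold lower number from compound 2 to compound 3 (0.78 log units; beyond the scatter) in this assay. Compound 3 is therefore estimated at 120 nM, within a range from 40 nM to 350 nM.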

Compound 3, inhibition constant: 67 nM
Beside the measured number, compound 3's estimate is 1.8-fold (0.25 log units) above it, within the range that was stated.
By their numbers in this assay, from the lowest: compounds 1 and 3 (each within the scatter of the next); then compound 2.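

Hydrogen in place of cyano on this aromatic carbon of the five-membered ring gives an 11-fold lower number from compound 2 to compound 3 (1.03 log units; beyond the scatter) in this assay, so a large part of the weaker binding of compound 2 is tied to this one place. Chloro in place of methyl gives a 1.4-fold higher number from compound 1 to compound 3 (0.15 log units; within the scatter), which means that this swap on the other aromatic carbon cannot be told apart from the scatter in these two compounds. No measurement shown here accounts for the size of the cyano step.

The compounds shown carry only hydrogen or cyano at this position, so how an amine, a carboxylic acid or a methoxy group would fare there remains open. Going by these compounds, it is also open whether cyano would cost as much with methyl in place of chloro.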